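Swapping an acetyl for a dimethylamino on a growth-inhibition scaffold

The compounds below may be only part of what the source reports. "The series", "measured", "known", "first", "only" and "open" are said of these compounds alone.

Measured compounds:
compound 1, `COc1cc(C)cc(-c2c(-c3ccnc(-c4ccc(C(C)=O)cc4)c3)cnn2CC#N)c1`: 3110 nM
compound 2, `COc1cc(C)cc(-c2nn(CC#N)cc2-c2ccc(-c3cccc(C(C)=O)c3)nc2)c1`: 3520 nM
compound 3, `COc1cc(C)cc(-c2nn(CC#N)cc2-c2ccnc(-c3ccc(N(C)C)cc3)c2)c1`: 420 nM

All three were tested in a functional assay on 786-0 cells (Homo sapiens) for inhibition, read by sulforhodamine B assay, with a stated time of 48 h; a lower number here means a stronger inhibitor of growth, a higher number a weaker inhibitor of growth. Compound 1 gives 3110 nM, which puts it second highest of the three numbers. Compound 2 sits nearest to it, and the gap between the two is within the usual scatter, so nothing can be said about their order. For the measured compounds named here, compound 3 stands furthest away with 420 nM, a clearly lower number, and it is the one compound here that carries a 4-(dimethylamino)phenyl group, although its core is joined in a different way from that of compound 1.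

Compound 4, `COc1cc(C)cc(-c2c(-c3ccnc(-c4ccc(N(C)C)cc4)c3)cnn2CC#N)c1`, has not yet been measured. It differs from compound 1 in one place: dimethylamino in place of acetyl on an aromatic carbon. Going by the values given here, no single-change step with the same swap exists among the measured compounds, so no measured step sets the size. Among the compounds with values here, the only hint comes from compound 3, whose value 420 nM shows that a dimethylamino-bearing analogue can reach a far lower number on this series.

On that basis compound 4 is expected to be a stronger growth inhibitor than compound 1, with the step of a 5.2-fold lower number from compound 1 to compound 4 (0.71 log units; beyond the scatter) going beyond the scatter. The estimate for compound 4 is 600 nM, with a range from 200 nM to 1800 nM.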

Compound 4, concentration for 50% growth inhibition: 85.3 nM
Compound 4: the middle estimate sits 7.0-fold (0.85 log units) above what was measured; measured number below the stated range.
By their numbers in this assay, from the lowest: compound 4; then compound 3; then compounds 1 and 2 (each within the scatter of the next).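

In this assay the change from 4-acetylphenyl to 4-(dimethylamino)phenyl on the shared core gives a 36-fold lower number from compound 1 to compound 4 (1.56 log units; beyond the scatter) and so shows that this single position, on an aromatic carbon para to a large group, has a large effect on the number. Both groups have 3 heavy atoms and the same count of hydrogen-bond acceptors, so neither count separates them, and the step must lie in some other difference between the two groups. Nothing measured here explains why this swap has so large an effect.

For the compounds shown here, this position is described by one step between only two groups, so no trend can be drawn from it. As far as these compounds go, it remains open whether a simple amino group, a methylamino group or a morpholine ring at the same place would give a number close to that of compound 4, or whether a carboxylic acid would give a much higher one.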